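This account rests on a few compounds, and the source may have more. Where it says the series, first, only, none or still open, it means among the compounds named here.

Working notes on the series. Compound 1 `O=C(/C=C/c1ccco1)c1ccccc1OCC1CO1` and compound 2 `O=C(/C=C/c1cccs1)c1ccccc1OCC1CO1` share one core; compound 3 `O=C(/C=C/c1ccco1)c1cccc(OCC2CO2)c1` carries the other. In a functional assay on MDA-MB-231 cells (Homo sapiens) for inhibition, read by CCK-8 assay and cell counting, with a stated time of 2 days (on this read-out higher numbers stand for weaker inhibition and lower numbers for stronger inhibition), compound 1 gives 28700 nM, compound 2 gives 17900 nM and compound 3 gives 27800 nM. The values of compound 1 and compound 3 lie within the scatter of each other, and the difference between the two cores is not broken down here.

Among the compounds with values here, the one measured step is a 1.6-fold lower number from compound 1 to compound 2 (0.21 log units; within the scatter), the change being (thiophen-2-yl in place of furan-2-yl on a double-bonded chain carbon bound to a double-bonded chain carbon).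

Compound 4 `O=C(/C=C/c1cccs1)c1cccc(OCC2CO2)c1` is not yet measured. It differs from compound 3 by thiophen-2-yl in place of furan-2-yl on a double-bonded chain carbon bound to a double-bonded chain carbon, the same change as that from compound 1 to compound 2, at the same place. Applying it to the core of compound 3 is expected to give a step of a 1.6-fold lower number from compound 3 to compound 4 (0.20 log units; within the scatter), set beside a 1.6-fold lower number from compound 1 to compound 2 (0.21 log units; within the scatter), and this expectation rests only on that single measured step, so it carries little weight. On that basis compound 4 is estimated at 17500 nM in this assay, most likely between 9000 nM and 35000 nM.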

Compound 4, half-maximal inhibitory concentration: 15400 nM
For compound 4 the middle estimate is 1.1-fold (0.06 log units) above the measured one; the measured number falls inside the stated range.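

In this assay the exchange of furan-2-yl for thiophen-2-yl on the second core gives a 1.8-fold lower number from compound 3 to compound 4 (0.26 log units; within the scatter), and set beside the earlier step on the first core it shows no difference that stands out: the same change on two cores in this assay, a 1.6-fold lower number (0.21 log units; within the scatter) from compound 1 to compound 2 and a 1.8-fold lower number (0.26 log units; within the scatter) from compound 3 to compound 4, 1.1-fold (0.05 log units) apart, within the scatter of two such steps. On these two cores, then, the change carries over with a step of much the same size, and nothing here points to a dependence on the core. This does not show that the change itself has an effect, since each step lies within the scatter and the agreement is only between two small steps; nor can two cores speak for any other core in the series.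

As far as these compounds go, only furan-2-yl and thiophen-2-yl appear at this place, so it remains open how a plain phenyl group or a ring carrying an amine would compare there. From the compounds shown here alone, it also remains open whether the step would hold on a core bearing a carboxylic acid or a longer chain.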